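A few compounds are considered here, and "the series" means these few. Any claim that something is new, unique, unknown or untested is made for them only; others in the source may bear on it.

Measured compounds and their results:

Compound 1 `COc1ccc(N2CCN(C(=S)SCc3ccc(C(=O)Nc4ccccc4N)cc3)CC2)cc1` — 52.3%
Compound 2 `Nc1ccccc1NC(=O)c1ccc(CSC(=S)N2CCc3cc(Cl)ccc32)cc1` — 65.1%
Compound 3 `CC1CCN(C(=S)SCc2ccc(C(=O)Nc3ccccc3N)cc2)CC1` — 72.5%

These three compounds share a core and were tested in a functional assay on HeLa cells (Homo sapiens) for antiproliferative activity, read by CCK-8 assay, with a stated time of 72 h, tested at 8 uM; a lower number here means a weaker effect, a higher number a stronger effect of the compound at the concentration tested. Compound 1 has the lowest number of the three: compound 2 sits higher by a gap beyond the usual scatter, and compound 3 higher still, also beyond the scatter. For the measured compounds named here, the one step between two compounds that differ in a single place, a number 7.4 percentage points higher from compound 2 to compound 3 (within the scatter), concerns the group on the thiocarbonyl carbon and lies within the scatter.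

Compound 4 `Nc1ccccc1NC(=O)c1ccc(CSC(=S)N2CCN(c3cnccn3)CC2)cc1` is not yet measured. It comes from compound 1 by a change at a different place: pyrazin-2-yl in place of 4-methoxyphenyl on an amine nitrogen in a ring. Going by the values given here, no measured step touches this amine nitrogen in the ring, so nothing in the data shows how such a swap moves the number. Compound 4 is therefore estimated to stay close to compound 1, with a broad range: 55% (35% to 75%). The expected step of a number 2.7 percentage points higher from compound 1 to compound 4 (within the scatter) is, on this estimate, not beyond the scatter.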

Compound 4, a percentage reported as inhibition, at one concentration (the size of the read-out at that concentration, not a potency): 76.9%
For compound 4 the middle estimate is 21.9 percentage points below the measured one; the measured number lies above the stated range.
By their numbers in this assay, from the lowest: compound 1; then compounds 2, 3 and 4 (each within the scatter of the next, the first and the last beyond it).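

In this assay, for the compounds shown here, the swap of 4-methoxyphenyl for pyrazin-2-yl gives a number 24.6 percentage points higher from compound 1 to compound 4 (beyond the scatter) and is the first measured change on this amine nitrogen in the ring. Going by these compounds alone, it shows that the number responds to the group carried here, which the earlier compounds could not show. The aromatic ring at this place also need not be of carbon only for the effect to be retained at the concentration tested, although no data at hand explain the size of the step.

The swap removes the methoxy group and brings in the 2 ring nitrogens together, so the compounds shown do not say which of the two goes with the higher number. A plain phenyl or a pyridin-2-yl group on this nitrogen would help to separate them.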